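The source may hold more compounds than are shown below. What is called first, only, known or untested is meant among the compounds shown, and "the series" means these compounds.

Values so far in a functional assay on HepG2 cells (Homo sapiens) for cytotoxicity, read by spectrophotometry, with a stated time of 72 h (on this read-out higher numbers stand for weaker inhibition and lower numbers for stronger inhibition), are
- compound 1 (`COc1cc(-n2c(-c3ccc([N+](=O)[O-])cc3)cccc2=O)cc(OC)c1OC`) gives < 10 nM as a limit
- compound 2 (`COc1cc(-n2c(-c3ccc(OC(F)(F)F)cc3)cccc2=O)cc(OC)c1OC`) gives 1960 nM as a number
- compound 3 (`COc1cc(-c2cccc(=O)n2-c2cc(OC)c(OC)c(OC)c2)cc(OC)c1OC`) gives 5460 nM as a number

Compound 1 stands at < 10 nM as a limit of the assay, not a number. Its place on the scale is known only through (the limit of < 10 nM in this assay, at which 1 of the 3 values shown sits) and no more closely than that.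

Compound 4 (`COc1cc(-n2c(-c3cccc(O)c3)cccc2=O)cc(OC)c1OC`) has not been measured yet. It carries 3-hydroxyphenyl in place of 4-nitrophenyl on an aromatic carbon next to the ring nitrogen (3-hydroxyphenyl in place of 4-nitrophenyl on an aromatic carbon).

The closest guide is the swap of nitro for trifluoromethoxy, which gave an at least 190-fold higher number from compound 1 to compound 2 (2.29 log units; beyond the scatter) and counts as a large step. It bears on this change since the nitro group leaves there too. Compound 3, with yet another group in that place, gives 5460 nM as its number. Among the measured compounds shown here, no measured compound carries 3-hydroxyphenyl, so the size of the change stays uncertain.

A clearly higher number, meaning weaker inhibition, is therefore expected, though the rise may be smaller than the one seen with trifluoromethoxy. The expected change is an at least 40-fold higher number from compound 1 to compound 4 (1.60 log units; beyond the scatter) by this estimate. For compound 4 the estimate is 400 nM with an expected range of 30 nM to 4000 nM in this assay once it is measured.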

Compound 4, half-maximal inhibitory concentration: 34 nM
Beside the measured number, compound 4's estimate is 12-fold (1.07 log units) above it; the range from low to high includes it.
By their numbers in this assay, from the lowest: compound 4; then compound 2; then compound 3. At a limit, below all of these: compound 1.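

In this assay compound 1 gives < 10 nM, which is a limit of the assay and not a number. Going by these compounds, with 3-hydroxyphenyl in place of 4-nitrophenyl on the aromatic carbon next to the ring nitrogen, the result is an at least 3.4-fold higher number from compound 1 to compound 4 (0.53 log units; beyond the scatter), and how large this step is stays open: the limit of < 10 nM in this assay, at which 1 of the 4 values shown sits. Compound 4 gives 34 nM while compound 2 gives 1960 nM, which shows that at this position the nitro group is not needed for a low number, and that its departure does not by itself lead to a number as high as that of compound 2.

The change from compound 1 to compound 4 replaces the group and moves it around the phenyl ring in a single step, so these compounds cannot tell whether the hydroxy group itself or its place on that ring accounts for the low number of compound 4. On these data alone, it also remains open how this position would respond to an amine or a carboxylic acid on the phenyl ring, or to a methoxy group in place of the hydroxy group of compound 4.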